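Pyrimidin-5-yl for 3-hydroxyphenyl: notes on compound 4

This account rests on a few compounds, and the source may have more. Where it says the series, first, only, none or still open, it means among the compounds named here.

Among the measured compounds shown here, in a physicochemical assay for solubility, using the shake flask method, in phosphate buffer, with a stated time of 24 h, at pH 7.4 (a lower number here means a less soluble compound, a higher number a more soluble compound), three compounds have numbers so far. Compound 1 (`Cn1ncc2c(=O)n(-c3ccccc3)c(COc3cccc(F)c3)nc21`) gives 194000 nM, and compound 2 (`CC(Sc1nc2c(cnn2C)c(=O)n1-c1ccccc1)c1cccnc1`) gives 209000 nM. Compound 3 (`CC(Sc1nc2c(cnn2C)c(=O)n1-c1ccccc1)c1cccc(O)c1`) gives 21000 nM, the lowest of the three numbers.

Compound 4 (`CC(Sc1nc2c(cnn2C)c(=O)n1-c1ccccc1)c1cncnc1`) has pyrimidin-5-yl in place of 3-hydroxyphenyl on a saturated chain carbon bound to a saturated chain carbon and a sulfur.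

For the measured compounds named here, one measured step bears directly on this change: a 10-fold lower number from compound 2 to compound 3 (1.00 log units; beyond the scatter). It is modest but beyond the scatter, and it involves the same 3-hydroxyphenyl at the same place. Going by the values given here, no measured compound carries pyrimidin-5-yl, so the reading rests on a single pair. Compound 4 shares with compound 2, at 209000 nM, a ring containing hetero atoms in place of 3-hydroxyphenyl, and it is therefore taken as the closest guide. A rise of similar size to that measured step, in the opposite direction, is expected in this assay. The expected change is a 9.5-fold higher number from compound 3 to compound 4 (0.98 log units; beyond the scatter). The estimated value for compound 4 is 200000 nM, with an expected range from 80000 nM to 400000 nM.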

Compound 4, solubility: 264000 nM
Compound 4: the middle estimate sits 1.3-fold (0.12 log units) below what was measured; the range from low to high includes it.
By their numbers in this assay, from the lowest: compound 3; then compounds 1, 2 and 4 (each within the scatter of the next).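

In this assay, pyrimidin-5-yl in place of 3-hydroxyphenyl on a saturated chain carbon bound to a saturated chain carbon and a sulfur gives a 13-fold higher number from compound 3 to compound 4 (1.10 log units; beyond the scatter) and is a large step, so compound 3 now stands apart from two partners carrying ring nitrogens, compound 2 and compound 4, instead of from compound 2 alone. Between those partners the exchange of pyridin-3-yl for pyrimidin-5-yl gives a 1.3-fold higher number from compound 2 to compound 4 (0.10 log units; within the scatter) and stays within the scatter, so at this position the two heteroaromatic rings cannot be told apart in this read-out, and the three compounds sharing this core form a pair and one outlier. Nothing available explains either step, and the size of the gap has no measured cause attached to it.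

Still open, as far as these compounds go, is where a plain phenyl ring would fall, which would show whether the hydroxyl group or the carbon-only ring goes with the lower number of compound 3. Also open, from the compounds shown here alone, is whether a pyridine ring bearing an amine or a carboxylic acid would stay with compound 2 and compound 4 or move away from them.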